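Plasma stability across a tripeptide enoate series

The source may report more compounds than this note shows. Statements on the series, on what has been measured and on what is new or still open speak of the compounds shown alone.

Values below come from an ADME assay on a cell-free system (plasma, Homo sapiens) for metabolic stability; on this read-out lower numbers stand for a shorter-lived compound and higher numbers for a longer-lived compound.
compound 1, `CCOC(=O)/C=C/[C@H](CC(C)C)NC(=O)[C@H](CC(C)C)NC(=O)[C@H](CC(C)C)NC(=O)C1=CCCN(C(=O)OC(C)(C)C)C1`: 3.3 h
compound 2, `CCOC(=O)/C=C/[C@H](CC(C)C)NC(=O)[C@H](CC(C)C)NC(=O)[C@H](CC(C)C)NC(=O)C1=CCCNC1`: > 6 h, an assay limit rather than a number
compound 3, `CCOC(=O)/C=C/[C@H](CC(C)C)NC(=O)[C@H](CO)NC(=O)[C@@H](NC(=O)C1=CCCN(C(=O)OC(C)(C)C)C1)C(C)C`: 2.57 h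

Compound 2 differs from compound 1 by hydrogen in place of tert-butoxycarbonyl on an amine nitrogen in a ring. On these data alone, the measured step is an at least 1.8-fold higher number from compound 1 to compound 2 (0.25 log units; that floor lies within the scatter); it stays open-ended because of the limit of > 6 h in this assay, at which 1 of the 3 values shown sits. Compound 3 stands next to compound 1 in this assay, and the two differ in more than one place, so the difference between the two cores is not broken down here.

Compound 4, `CCOC(=O)/C=C/[C@H](CC(C)C)NC(=O)[C@H](CO)NC(=O)[C@@H](NC(=O)C1=CCCNC1)C(C)C`, is not yet measured. Going by the values given here, it differs from compound 3 by hydrogen in place of tert-butoxycarbonyl on an amine nitrogen in a ring, the same change as the one from compound 1 to compound 2, made on the core of compound 3.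

Compound 4 is expected to give 5.5 h in this assay. The expected range for compound 4 runs from 3 h to 12 h. The step this estimate means is a 2.1-fold higher number from compound 3 to compound 4 (0.33 log units; beyond the scatter), and it rests on the measured at least 1.8-fold higher number from compound 1 to compound 2 (0.25 log units; that floor lies within the scatter) carried over to the value of compound 3, with a real chance that only a limit is reported.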

Compound 4, half-life: > 6 h
Compound 4 gave a limit, no number (the forecaster's own chance of this, stated with the estimate: 45%); at least 1.0-fold (0.03 log units) between middle value and limit.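

In this assay the replacement of tert-butoxycarbonyl by hydrogen on an amine nitrogen in a ring gives an at least 2.3-fold higher number from compound 3 to compound 4 (0.36 log units; beyond the scatter) on the core of compound 3, a step beyond the scatter. Compound 4 reads > 6 h as a limit of the assay, not a number. On these data alone, the change thus carries over to a second core with a higher number on both, but its size on either core remains unknown, and equal size cannot be claimed: the same change on two cores in this assay, an at least 1.8-fold higher number (0.25 log units; that floor lies within the scatter) from compound 1 to compound 2 and an at least 2.3-fold higher number (0.36 log units; beyond the scatter) from compound 3 to compound 4; the limit leaves it open whether they differ.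

As far as these compounds go, the true half-lives of the two compounds with hydrogen on the ring nitrogen remain open, and so does any ranking of the two cores once that group is hydrogen. Also open, from the compounds shown here alone, is whether a small acetyl or methyl group on that nitrogen would read like hydrogen or like tert-butoxycarbonyl, and whether a carboxylic acid in place of the ethyl ester would change the picture.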